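This account rests on a few compounds, and the source may have more. Where it says the series, first, only, none or still open, it means among the compounds named here.

Measured so far:
compound 1, `COc1ccc(-c2cc(=O)c3c(OC)cc(OC)cc3n2S(=O)(=O)c2cccc([N+](=O)[O-])c2)cc1`, gives > 39600 nM;
compound 2, `COc1ccc(-c2cc(=O)c3c(OC)cc(OC)cc3n2S(=O)(=O)c2c(C(C)C)cc(C(C)C)cc2C(C)C)cc1`, gives 43300 nM.

Both were tested in a functional assay on SUP-B15 cells (Homo sapiens) for antiproliferative activity, with a stated time of 72 h; a lower number here means that less compound is needed, a higher number that more compound is needed for the effect. For compound 1 the value is a limit of the assay and not a number; compound 1 gives > 39600 nM in this assay. Compound 2 gives 43300 nM in this assay, a number rather than a limit. Taken together, neither compound reaches an effect at the concentrations that were usable, which is what the limit of > 39600 nM in this assay, at which 1 of the 2 values shown sits, records for compound 1.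

Compound 3, `COc1ccc(-c2cc(=O)c3c(OC)cc(OC)cc3n2S(=O)(=O)c2ccc(Br)s2)cc1`, has not yet been measured in this assay. It differs from compound 1 at the sulfonyl sulfur: 5-bromothiophen-2-yl in place of 3-nitrophenyl on a sulfonyl sulfur. The shared core of compound 1 stays unchanged.

For the measured compounds named here, since no measured step between two compounds is available, the expectation for compound 3 rests on the two values alone, which both sit at the weak end of this assay. The step from compound 1 to compound 3 is expected to be a step that the limit leaves unreadable from compound 1 to compound 3, that is, no change beyond the scatter. Compound 3 is therefore estimated at 40000 nM, within a range from 15000 nM to 100000 nM, with a fair chance that this assay again reports only a limit.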

Compound 3, half-maximal effective concentration: > 48200 nM
Compound 3: a limit, no number; the forecaster's own chance of this, stated with the estimate: 60%; middle value at least 1.2-fold (0.08 log units) from the limit.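

In this assay compound 3 gives > 48200 nM, which is a limit and not a number. Compound 1 also gives a limit, and no step can be read between compound 1 and compound 3. The compounds shown leave open whether changing the group on the sulfonyl sulfur can change the result in this assay at all.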